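A few compounds are considered here, and "the series" means these few. Any claim that something is new, unique, unknown or untested is made for them only; others in the source may bear on it.

In an assay on HEK-293T cells for inhibition of diacylglycerol lipase-alpha (Homo sapiens), read by colorimetric assay (on this read-out lower numbers stand for stronger inhibition and higher numbers for weaker inhibition), compound 1 `O=C(CCCCCCc1ccccc1)c1nncs1` gives only a limit, > 10000 nM, and that limit is noted in the limit of > 10000 nM in this assay, at which 1 of the 3 values shown sits. Compound 2 `CS(=O)(=O)c1coc(C(=O)CCCCCCc2ccccc2)n1` gives 389 nM in this assay, and compound 3 `CC(C)(C)C(=O)c1coc(C(=O)CCCCCCc2ccccc2)n1` gives 479 nM, the higher of the two numbers reported, its nearest neighbour being compound 2. Going by the values given here, the only step measured so far, a 1.2-fold higher number from compound 2 to compound 3 (0.09 log units; within the scatter), concerns the same aromatic carbon. Compound 4 `O=Cc1coc(C(=O)CCCCCCc2ccccc2)n1` differs from compound 3 by hydrogen in place of tert-butyl on a carbonyl carbon, so the carbonyl stays while the tert-butyl is lost. Since that one step was within the scatter, the change for compound 4 is expected to be a 1.0-fold higher number from compound 3 to compound 4 (0.02 log units; within the scatter), with no clear direction. Compound 4 is therefore estimated at 500 nM, ranging from 150 nM to 2000 nM.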

Compound 4, half-maximal inhibitory concentration: 1510 nM
Beside the measured number, compound 4's estimate is 3.0-fold (0.48 log units) below it, within the range that was stated.
By their numbers in this assay, from the lowest: compounds 2 and 3 (each within the scatter of the next); then compound 4. At a limit, above all of these: compound 1.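

Removing tert-butyl from the carbonyl carbon weakens inhibition in this assay (a 3.2-fold higher number from compound 3 to compound 4 (0.50 log units; beyond the scatter)), so this position responds to a change, though methylsulfonyl and (tert-butyl)carbonyl on the aromatic carbon had stayed within the scatter of each other. Formyl also falls behind methylsulfonyl (a 3.9-fold higher number from compound 2 to compound 4 (0.59 log units; beyond the scatter)). Even so, 4-formyl-1,3-oxazol-2-yl still improves on 1,3,4-thiadiazol-2-yl (an at least 6.6-fold lower number from compound 1 to compound 4 (0.82 log units; beyond the scatter)), a step that rests on a limit: the limit of > 10000 nM in this assay, at which 1 of the 4 values shown sits. Still open, as far as these compounds go, is whether methyl or an amine on that carbonyl carbon would sit nearer compound 3 or compound 4.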